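Chain extension on the acyl group of a triazene

The compounds below may be only part of what the source reports. "The series", "measured", "known", "first", "only" and "open" are said of these compounds alone.

Measured so far:
compound 1 `CCC(=O)N[C@@H](C)C(=O)N(C)/N=N/c1ccc(C#N)cc1` – 10.1 h
compound 2 `CC(=O)NCC(=O)N(C)/N=N/c1ccc(C#N)cc1` – 7.6 h

In a physicochemical assay for metabolic stability, read by HPLC, in phosphate buffer, at pH 7.7 (on this read-out lower numbers stand for a shorter-lived compound and higher numbers for a longer-lived compound), compound 1 gives 10.1 h, the higher of the two numbers recorded, though the step of a 1.3-fold lower number from compound 1 to compound 2 (0.12 log units; within the scatter) is within the scatter, so compound 1 and compound 2 cannot be set in order. That step replaced the propanoyl-alanine arm with an acetyl-glycine arm on the carbonyl carbon and left the read-out essentially unchanged.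

Compound 3 `CCCC(=O)N[C@@H](C)C(=O)N(C)/N=N/c1ccc(C#N)cc1` has not yet been measured in this assay. It differs from compound 1 by methyl in place of hydrogen on a saturated chain carbon, two bonds along the chain from a carbonyl carbon, that is, propanoyl to propylcarbonyl on the acyl chain. Among the measured compounds shown here, the only measured step bears on it indirectly: the larger change from compound 1 to compound 2 stayed within the scatter, and adding one methyl at the far end of the chain is a smaller alteration still. He therefore expects no step beyond the scatter from compound 1 to compound 3 in this assay, written as a 1.0-fold higher number from compound 1 to compound 3 (0.02 log units; within the scatter). For compound 3 the estimated half-life is 10.5 h, expected to lie between 6 h and 19 h.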

Compound 3, half-life: 9.1 h
Beside the measured number, compound 3's estimate is 1.2-fold (0.06 log units) above it, within the range that was stated.
By their numbers in this assay, from the lowest: compounds 2, 3 and 1 (each within the scatter of the next).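

In this assay, the change from propanoyl to propylcarbonyl gives a 1.1-fold lower number from compound 1 to compound 3 (0.05 log units; within the scatter), so methyl in place of hydrogen at this place on the acyl chain does not separate the two compounds. The earlier step changed the whole arm on the carbonyl carbon, whereas this one changes a single place at the end of the acyl chain, and it shows that this one-carbon extension of compound 1 leaves the half-life within the scatter. Nothing on hand accounts for this result.

The compounds shown leave open whether a longer chain, or an amine or a carboxylic acid at the end of the acyl chain, would give a step beyond the scatter in this assay. They also leave open whether the same methyl added to the acetyl-glycine arm of compound 2 would read the same way, so the finding holds only for the arm of compound 1.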